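The compounds below may be only part of what the source reports. "The series", "measured", "known", "first", "only" and "open" are said of these compounds alone.

Compound 1 `Cc1ccc(S(=O)(=O)c2nc3ccccc3nc2Nc2ccccc2)cc1` carries an anilino group on the shared core and, in a functional assay on PC-3 cells (Homo sapiens) for cytotoxicity, read by MTT assay, with a stated time of 72 h (a higher number here means a weaker inhibitor, a lower number a stronger inhibitor), compound 1 gives 1060 nM. Compound 3 `COc1ccc(S(=O)(=O)c2nc3ccccc3nc2Nc2ccccc2)cc1` differs from compound 1 only by methoxy in place of methyl on an aromatic carbon, and in this assay compound 3 gives 1260 nM; the step of a 1.2-fold higher number from compound 1 to compound 3 (0.08 log units; within the scatter) is small. Compound 2 `COc1ccc(Nc2nc3ccccc3nc2S(=O)(=O)c2ccc(C)cc2)cc1` differs from compound 1 by methoxy in place of hydrogen on an aromatic carbon. In this assay compound 2 reaches only a limit, > 50000 nM, which is the limit of > 50000 nM in this assay, at which 1 of the 3 values shown sits. The step of an at least 47-fold higher number from compound 1 to compound 2 (1.67 log units; beyond the scatter) is therefore large.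

Compound 4 `COc1ccc(Nc2nc3ccccc3nc2S(=O)(=O)c2ccc(OC)cc2)cc1` is not yet measured. It differs from compound 3 by methoxy in place of hydrogen on an aromatic carbon, the same change that separates compound 1 from compound 2, at the same place. The two cores differ by methoxy in place of methyl on an aromatic carbon, a change that moved the number very little. The same large step is expected again, a 40-fold higher number from compound 3 to compound 4 (1.60 log units; beyond the scatter), because the change repeats an at least 47-fold higher number from compound 1 to compound 2 (1.67 log units; beyond the scatter). Compound 4 is therefore expected to give about 50000 nM in this assay, with a range from 12000 nM to 200000 nM, and quite possibly only a limit.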

Compound 4, half-maximal inhibitory concentration: 8710 nM
The estimate for compound 4 lay 5.7-fold (0.76 log units) above the measured number; the whole stated range lies above it.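

In this assay, the change from anilino to (4-methoxyphenyl)amino again gives a higher number, a 6.9-fold higher number from compound 3 to compound 4 (0.84 log units; beyond the scatter), so its direction carries over from the core of compound 1 to the core of compound 3, but its size does not: the same change on two cores in this assay, an at least 47-fold higher number (1.67 log units; beyond the scatter) from compound 1 to compound 2 and a 6.9-fold higher number (0.84 log units; beyond the scatter) from compound 3 to compound 4, at least 6.8-fold (0.83 log units) apart, beyond the scatter of two such steps Methoxy in place of methyl on an aromatic carbon does not carry over unchanged either, giving an at least 5.7-fold lower number from compound 2 to compound 4 (0.75 log units; beyond the scatter) once the (4-methoxyphenyl)amino group is present: the same change on two cores in this assay, a 1.2-fold higher number (0.08 log units; within the scatter) from compound 1 to compound 3 and an at least 5.7-fold lower number (0.75 log units; beyond the scatter) from compound 2 to compound 4, at least 6.8-fold (0.83 log units) apart, beyond the scatter of two such steps The value of compound 2, > 50000 nM, is a limit, and these pairs do not show why the steps differ or how either change would run on any further core.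

The compounds shown leave open whether the same dependence on the core appears with another group in the place of methoxy, such as a fluorine atom or a dimethylamino group. They also leave open what a benzylamino group in the place of the anilino group would do to these steps.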